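The compounds below may be only part of what the source reports. "The series", "measured", "known", "first", "only" and "open" are said of these compounds alone.

Measured compounds:
- compound 1 `CC(C)C1=CC[C@H](CO)[C@@]12C=CC(=O)CC2`; in an ADME assay on BJ cells (Homo sapiens) for cytotoxicity, with a stated time of 72 h (a lower number here means that less compound is needed, a higher number that more compound is needed for the effect), compound 1 gives > 90000 nM, a limit of the assay.
- compound 2 `CC1=CC[C@@]2(CC1)C(C(C)C)=CC[C@@H]2CO`; in this assay compound 2 gives > 90000 nM, a limit of the assay.
- compound 3 `C=C1CC[C@H](C(=O)OCC)[C@@]12C=CC(=O)CC2`; in this assay compound 3 gives > 90000 nM, a limit of the assay.

Compound 1 stands at the edge of what this assay can report: its value is a limit, not a number, and the same holds for the other two compounds shown (the limit of > 90000 nM in this assay, at which 3 of the 3 values shown sit). Among the compounds with values here, no pair of measured compounds differs in a single place, so no measured step is available from which to read a direction.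

Compound 4 `CC(C)C1=CC[C@H](C(=O)O)[C@@]12C=CC(=O)CC2` is the next compound for this assay. It differs from compound 1 by carboxy in place of hydroxymethyl on a saturated ring carbon. With all three measured compounds sitting at the limit, the expected step that the limit leaves unreadable from compound 1 to compound 4 is none beyond the scatter, in either direction. Compound 4 is therefore expected to come out again as a limit, estimated at 100000 nM, with a range from 40000 nM to 300000 nM.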

Compound 4, half-maximal effective concentration: > 90000 nM
Compound 4 ended at the assay's limit; the forecaster's own chance of this, stated with the estimate: 85%; the middle value does not contradict the limit.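

Carboxy in place of hydroxymethyl gives no readable step between compound 1 and compound 4 in this assay, because both values are limits of the assay: the limit of > 90000 nM in this assay, at which 4 of the 4 values shown sit.

The compounds shown leave open whether any change to the shared core brings a value off this limit, and in which direction.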